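A few compounds are considered here, and "the series" means these few. Any claim that something is new, unique, unknown or untested is made for them only; others in the source may bear on it.

Compound 1 `CC(=O)OCC(C)(C)COC1(c2ccc(Cl)cc2)c2ccccc2C(=O)N1Cc1ccc(Cl)cc1` carries a 2-(acetoxymethyl)-2-methylpropoxy chain on the shared core. Within the data shown here, in a functional assay on HCT-116 cells (Homo sapiens) for inhibition, read by fluorescence, with a stated time of 48 h (a higher number here means a weaker inhibitor of growth, a lower number a stronger inhibitor of growth), compound 1 gives 35000 nM, the higher of the two numbers measured so far. Compound 2 `CC(C)(COC(=O)[C@@H](N)c1ccccc1)COC1(c2ccc(Cl)cc2)c2ccccc2C(=O)N1Cc1ccc(Cl)cc1` differs from it only in the acyl group of that ester, and in this assay compound 2 gives 8000 nM; the step of a 4.4-fold lower number from compound 1 to compound 2 (0.64 log units; beyond the scatter) shows that an amino(phenyl)methyl in place of methyl on the carbonyl carbon moves the number by a modest amount.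

Compound 3 `O=C1c2ccccc2C(OCCCO)(c2ccc(Cl)cc2)N1Cc1ccc(Cl)cc1` is not yet measured. Its difference from compound 1 is 2-hydroxyethyl in place of 1-(acetoxymethyl)-1-methylethyl on a saturated chain carbon bound to an oxygen on a saturated carbon. Among the measured compounds shown here, no measured step matches this change: the one step known alters the acyl part of the ester, whereas here the whole ester and the two methyl groups are removed and a 3-hydroxypropoxy chain remains. That step therefore bears only loosely on the question, and without a closer precedent compound 3 is expected to stay near compound 1, with a step of a 1.1-fold higher number from compound 1 to compound 3 (0.06 log units; within the scatter) that is expected to lie within the scatter. In this assay compound 3 is estimated at 40000 nM, with a range from 15000 nM to 100000 nM.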

Compound 3, concentration for 50% growth inhibition: 60000 nM
For compound 3 the middle estimate is 1.5-fold (0.18 log units) below the measured one; the range from low to high includes it.
By their numbers in this assay, from the lowest: compound 2; then compounds 1 and 3 (each within the scatter of the next).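

Removing the whole ester and the two methyl groups, so that only a 3-hydroxypropoxy chain remains on the shared core, gives a 1.7-fold higher number from compound 1 to compound 3 (0.23 log units; within the scatter) in this assay. The earlier step had changed only the acyl part of the ester, whereas this one shows that in this series the number does not distinguish the 2-(acetoxymethyl)-2-methylpropoxy chain from the far smaller 3-hydroxypropoxy chain, so the acetate ester and the two methyl groups together are not needed to keep it at this level. No independent measurement is available to explain why these two chains read alike.

The compounds shown leave open what the amino(phenyl)methyl group of compound 2 requires, for example whether a simple amine at the end of the chain in place of the hydroxyl would lower the number as that ester does, or whether the phenyl ring is also needed. They also do not separate the two methyl groups from the ester, which a 3-hydroxy-2,2-dimethylpropoxy chain would do, and they leave untested a carboxylic acid or a longer chain at this position.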